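Chain Lengthening and Metabolic Half-Life in a Carbamate Series

This account rests on a few compounds, and the source may have more. Where it says the series, first, only, none or still open, it means among the compounds named here.

The measured compounds and their values:
compound 1, `CCCCCNC(=O)Oc1ccc(Cl)cc1C(=O)Nc1cccc(Cl)c1`, 43 h
compound 2, `CCCCCCNC(=O)Oc1ccc(Cl)cc1C(=O)Nc1cccc(Cl)c1`, 43 h
compound 3, `CCCCCCCNC(=O)Oc1ccc(Cl)cc1C(=O)Nc1ccc(Cl)cc1`, 43 h

In an ADME assay for metabolic stability, read by HPLC, at pH 7.4 (on this read-out higher numbers stand for a longer-lived compound and lower numbers for a shorter-lived compound), compound 1 gives 43 h. Compound 2 differs from it by methyl in place of hydrogen on a saturated chain carbon, five bonds along the chain from an amide-type nitrogen, and this change gave no change at the digits printed from compound 1 to compound 2 (within the scatter). Compound 3 gives 43 h in this assay, level with compounds 1 and 2; the difference between the core of compound 3 and the core of compound 1 is not broken down here.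

Compound 4, `CCCCCCCCNC(=O)Oc1ccc(Cl)cc1C(=O)Nc1ccc(Cl)cc1`, has not yet been measured. It differs from compound 3 by methyl in place of hydrogen on a saturated chain carbon, seven bonds along the chain from an amide-type nitrogen. The place is not the same as in the change from compound 1 to compound 2: there the methyl enters five bonds along the chain from an amide-type nitrogen, here seven bonds along, so it is the same kind of change rather than the same change. Because no change at the digits printed from compound 1 to compound 2 (within the scatter) stayed within the scatter, the step from compound 3 to compound 4 is expected to be no change at the digits printed from compound 3 to compound 4 (within the scatter). Compound 4 is therefore estimated at 43 h, with an expected range from 22 h to 86 h.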

Compound 4, half-life: 43 h
Compound 4: the middle estimate sits on the measured number at the digits printed, and the stated range covers the measured number.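

In this assay, methyl in place of hydrogen on a saturated chain carbon, seven bonds along the chain from an amide-type nitrogen, gave no change at the digits printed from compound 3 to compound 4 (within the scatter). Set beside the earlier step on the core of compound 1, the lengthening by one carbon carries over to the core of compound 3 with no difference that stands out from the scatter: the same change on two cores in this assay, no change at the digits printed (within the scatter) from compound 1 to compound 2 and no change at the digits printed (within the scatter) from compound 3 to compound 4, 1.0-fold (0.00 log units) apart, within the scatter of two such steps. Among these compounds, this rests on only one pair of cores, and the methyl enters five bonds along in one step and seven bonds along in the other, so the core and the place are not separated; and since both steps leave the half-life level, they do not show how a change that did move the half-life would carry from one core to the other.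

The compounds shown leave open whether a longer chain, a branched chain, or a chain carrying an amine or a carboxylic acid would hold the same half-life on either core. They also leave open whether the same step would stay level on any third core.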